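Amide variation on the shared core: outlook for compound 4

This account rests on a few compounds, and the source may have more. Where it says the series, first, only, none or still open, it means among the compounds named here.

The series keeps one shared core and varies the aryl group on the carbonyl carbon of the amide. Compound 1 `O=C(Nc1ccc(Cl)c(-c2nnc3c(Cl)cccn23)c1)c1cccnc1` carries pyridin-3-yl there; in a functional assay on HeLa cells (Homo sapiens) for antiproliferative activity, read by MTT assay, with a stated time of 72 h (on this read-out lower numbers stand for stronger inhibition and higher numbers for weaker inhibition), compound 1 returns only a limit, > 100000 nM. Compound 2 `O=C(Nc1ccc(Cl)c(-c2nnc3c(Cl)cccn23)c1)c1cccc(Cl)c1` carries 3-chlorophenyl; in this assay compound 2 likewise returns only a limit, > 100000 nM. Compound 3 `O=C(Nc1ccc(Cl)c(-c2nnc3c(Cl)cccn23)c1)c1c(F)cccc1Cl` carries 2-chloro-6-fluorophenyl; in this assay compound 3 also returns only a limit, > 100000 nM. Compound 3 therefore stands nowhere distinguishable among the three: all values sit at the same limit, as summed up in the limit of > 100000 nM in this assay, at which 3 of the 3 values shown sit, and the steps a step that the two limits leave unreadable from compound 1 to compound 2, a step that the two limits leave unreadable from compound 1 to compound 3 and a step that the two limits leave unreadable from compound 2 to compound 3 are unreadable in size.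

Compound 4 `O=C(Nc1ccc(Cl)c(-c2nnc3c(Cl)cccn23)c1)c1cccnc1Cl` is the next member. The change from compound 3: 2-chloropyridin-3-yl in place of 2-chloro-6-fluorophenyl on a carbonyl carbon. The measured steps touching this carbonyl position all bear on it, yet none tells a size. Since every variation tried at this position sits at the limit described in the limit of > 100000 nM in this assay, at which 3 of the 3 values shown sit, compound 4 is expected to behave alike. The estimated step that the limit leaves unreadable from compound 3 to compound 4 is expected to mean no readable change in this assay. For compound 4 the expected value in this assay is 150000 nM, with a range from 50000 nM to 500000 nM, most likely again reported only as a limit.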

Compound 4, half-maximal inhibitory concentration: 87500 nM
Compound 4: middle estimate off by 1.7-fold (0.23 log units), on the high side, within the range that was stated.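

At the carbonyl position, compound 4 is the only member that gives a number in this assay, while the others remain at the assay limit: the limit of > 100000 nM in this assay, at which 3 of the 4 values shown sit.

The earlier values are limits. The new comparisons give only floors, not step sizes: an at least 1.1-fold lower number from compound 3 to compound 4 (0.05 log units; that floor lies within the scatter), an at least 1.1-fold lower number from compound 2 to compound 4 (0.05 log units; that floor lies within the scatter), and, for the change of chloro in place of hydrogen on an aromatic carbon, an at least 1.1-fold lower number from compound 1 to compound 4 (0.05 log units; that floor lies within the scatter). Each floor lies within the scatter, so neither 2-chloropyridin-3-yl nor this single chloro can yet be credited with a real gain in this assay.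

The steps among compound 1, compound 2 and compound 3 cannot be read, so no order can be set among pyridin-3-yl, 3-chlorophenyl and 2-chloro-6-fluorophenyl. On these data alone, whether a dimethylamino group or a carboxylic acid in place of the chloro of compound 4 would give a step clear of the scatter remains open.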